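This account rests on a few compounds, and the source may have more. Where it says the series, first, only, none or still open, it means among the compounds named here.

Compound 1 `O=C1c2c[n+]([O-])c3ccccc3c2C(=O)c2[nH]c3ccccc3c21` in a functional assay on A-375 cells (Homo sapiens) for cytotoxicity, read by MTT assay, with a stated time of 72 h (a lower number here means a stronger inhibitor, a higher number a weaker inhibitor), gives 660 nM, the highest of the three numbers recorded, though its gaps to the other two lie within the scatter. Among the compounds with values here, compound 2 `CC1(C)OCC(Cn2cc(Cn3c4c(c5ccccc53)C(=O)c3c[n+]([O-])c5ccccc5c3C4=O)nn2)O1` gives 330 nM and compound 3 `CC1(C)OC[C@@H](Cn2cc(Cn3c4c(c5ccccc53)C(=O)c3c[n+]([O-])c5ccccc5c3C4=O)nn2)O1` gives 450 nM in this assay; the only step recorded between them, a 1.4-fold higher number from compound 2 to compound 3 (0.13 log units; within the scatter), rests on the fact that one of compounds 2 and 3 is drawn with a defined configuration and the other without, at the place where they differ and does not bear on the change considered here. Compound 4 `O=C1c2c[n+]([O-])c3ccccc3c2C(=O)c2c1c1ccccc1n2CCCN1CCC(O)CC1` carries 3-(4-hydroxypiperidin-1-yl)propyl in place of hydrogen on an aromatic nitrogen. Within the data shown here, no measured step covers a change of this kind; compounds 2 and 3 only show that a group on the same aromatic nitrogen leaves the number near that of compound 1. The step is therefore expected to stay within the scatter, a 1.5-fold lower number from compound 1 to compound 4 (0.17 log units; within the scatter). Compound 4 is estimated at 450 nM, ranging from 150 nM to 1300 nM.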

Compound 4, half-maximal inhibitory concentration: 240 nM
For compound 4 the middle estimate is 1.9-fold (0.27 log units) above the measured one, and the stated range covers the measured number.
By their numbers in this assay, from the lowest: compounds 4, 2, 3 and 1 (each within the scatter of the next, the first and the last beyond it).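

Substitution on the aromatic nitrogen now gives a step beyond the scatter in this assay: a 2.8-fold lower number from compound 1 to compound 4 (0.44 log units; beyond the scatter). The groups of compounds 2 and 3 on the same nitrogen stayed within the scatter of compound 1, while compound 4 lies within the scatter of compound 2, so 3-(4-hydroxypiperidin-1-yl)propyl stands apart only against compound 1. Nothing at hand bears on the reason for this step.

Open, going by these compounds, is whether the step depends on the hydroxyl group, which an unsubstituted piperidine or a morpholine on the same propyl chain would test. Also open, on these data alone, is how an ethyl or butyl chain carrying the 4-hydroxypiperidine would compare.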